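The source may report more compounds than this note shows. Statements on the series, on what has been measured and on what is new or still open speak of the compounds shown alone.

Measured so far:
compound 1, `c1ccc2c(NC3CCCCCC3)nc(N3CCC(N4CCCC4)CC3)nc2c1` — 10%
compound 2, `COc1cc2nc(N3CCC(N4CCCC4)CC3)nc(N(C)C)c2cc1OC` — < 0%

In an in vitro functional assay on B300-19 cells for antagonist activity at C-C chemokine receptor type 4 (Homo sapiens), read by GTPgammaS binding, tested at 1 uM (on this read-out higher numbers stand for more inhibition at the one concentration tested (going by the name of the read-out) and lower numbers for less inhibition), compound 1 gives 10%, a small amount of inhibition at the one concentration tested. For compound 2 this assay gives no number but only a limit, < 0%, which is the point (the limit of < 0% in this assay, at which 1 of the 2 values shown sits); compound 2 therefore stands at the floor of what can be reported. Both values are low, and nothing beyond that can be read from the pair.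

Compound 3, `COc1cc2nc(N3CCC(N4CCCC4)CC3)nc(N3CCCCC3)c2cc1OC`, has not yet been measured. It differs from compound 2 in one place: piperidin-1-yl in place of dimethylamino on an aromatic carbon. Among the compounds with values here, no step between two measured compounds tracks this kind of change, so the expectation rests only on the two values above. Compound 1, which carries a quite different group in the shared core, gives 10%, and this suggests that such changes do little here. Compound 3 is therefore expected to show a step of a number at least 5 percentage points higher from compound 2 to compound 3 (that floor lies within the scatter) in this assay, a change no bigger than the usual scatter. Compound 3 is expected to give 5%, with a range from -10% to 20%.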

Compound 3, a percentage reported as inhibition, at one concentration (the size of the read-out at that concentration, not a potency): 8%
The estimate for compound 3 lay 3 percentage points below the measured number; the range from low to high includes it.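

In this assay, within the data shown here, putting piperidin-1-yl in place of dimethylamino on this aromatic carbon, next to the ring nitrogen, gives a number at least 8 percentage points higher from compound 2 to compound 3 (that floor lies within the scatter), the first step that can be read at this place. The ring group therefore leaves compound 3 at 8%, a small amount of inhibition at the one concentration tested, so a non-aromatic six-membered ring here does not by itself bring strong inhibition. The true size of the step stays unknown because compound 2 is reported only as a limit, and the step is therefore a floor and not a measured difference: the limit of < 0% in this assay, at which 1 of the 3 values shown sits.

The compounds shown leave open whether another group at this place, such as morpholin-4-yl with its ring oxygen or a benzylamine with its aromatic ring and amine hydrogen, would raise the inhibition clearly beyond the usual scatter. Going by these compounds, compound 1 differs from compound 2 and compound 3 in more than one place, so the separate roles of its cycloheptylamino group and of the two methoxy groups on the shared core also remain open.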